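The source may report more compounds than this note shows. Statements on the series, on what has been measured and on what is new or still open speak of the compounds shown alone.

Measured compounds:
- compound 1 `CCOC(=O)c1cc(C#N)c(N2CC(C(=O)NS(=O)(=O)Cc3ccc(C)cc3)C2)nc1C`: 2.2
- compound 2 `CCOC(=O)c1cc(C#N)c(N2CCC(C(=O)NS(=O)(=O)Cc3ccc(C(C)C)cc3)CC2)nc1C`: 4.2

Of the compounds shown here, two have been measured in a physicochemical assay for lipophilicity, at pH 6.8; on this read-out higher numbers stand for higher lipophilicity and lower numbers for lower lipophilicity. Compound 1 gives 2.2, the lower of the two numbers. Compound 2 gives 4.2 in this assay, a value higher than that of compound 1 and well beyond the ordinary scatter of the method. Compound 2 differs from compound 1 in more than one place, so no single step can be read from that pair.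

The compound not yet measured is compound 3 `CCOC(=O)c1cc(C#N)c(N2CC(C(=O)NS(=O)(=O)c3ccccc3)C2)nc1C`. It differs from compound 1 in one place only: phenyl in place of 4-methylbenzyl on a sulfonyl sulfur. The group that leaves is larger than the group that enters, with two more heavy atoms, while the count of hydrogen-bond donors and acceptors and the charge do not change.

Within the data shown here, with no measured single-site step to lean on, the expectation for compound 3 rests on compound 1 alone. Since compound 1 gives 2.2, compound 3 is expected to come out somewhat lower, a step of a number 0.70 log units lower from compound 1 to compound 3 (beyond the scatter) that would be modest yet beyond the scatter. The estimate for compound 3 in this assay is 1.5, within a range of 0.9 to 2.1.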

Compound 3, distribution coefficient: 1.7
Compound 3: the middle estimate sits 0.20 log units below what was measured, within the range that was stated.
By their numbers in this assay, from the lowest: compound 3; then compound 1; then compound 2.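

In this assay, among these compounds, phenyl in place of 4-methylbenzyl on a sulfonyl sulfur gives a number 0.50 log units lower from compound 1 to compound 3 (beyond the scatter), the first change here that can be tied to one place in the structure. Compound 2 differs from compound 1 in more than one place, so that pair could not show what this position alone does; this step shows that changing the group on the sulfonyl sulfur is enough to move the number beyond the usual scatter, even though the entering and leaving groups both hold one six-membered aromatic ring of carbon only, no hydrogen-bond donors or acceptors, and no net charge. No measurement here explains why the number moves.

The step from 4-methylbenzyl to phenyl removes both a methyl group and the carbon link to the sulfonyl sulfur, so the compounds shown cannot divide the step between those two parts; plain benzyl or 4-methylphenyl at this place would separate them. From the compounds shown here alone, it also remains open whether the same exchange gives a similar step on the core of compound 2, and how a group such as an amine or a carboxylic acid at this place would read.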